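Methyl in place of 4-fluorophenyl on the ring amine

This account rests on a few compounds, and the source may have more. Where it says the series, first, only, none or still open, it means among the compounds named here.

Compound 1 `CS(=O)(=O)c1ccc(C(=O)N2CCC(C(=O)N3CCN(c4ccc(F)cc4)CC3)CC2)cc1[N+](=O)[O-]` is the reference point of this set. In an ADME assay on HepG2 cells (Homo sapiens) for cytotoxicity, read by CellTiter-Glo and ATP content, with a stated time of 72 h (on this read-out higher numbers stand for an effect only at larger amounts of compound and lower numbers for an effect already at smaller amounts), compound 1 gives > 27000 nM, which is a limit of the assay and not a number. Compound 2 `CC(C)N(C(=O)CCNC(=O)c1ccc(S(C)(=O)=O)c([N+](=O)[O-])c1)C(C)C` is the second measured compound. In this assay compound 2 gives > 27000 nM, again a limit rather than a number. Compound 3 `CN(Cc1cccc(F)c1)C(=O)CCCNC(=O)c1ccc(S(C)(=O)=O)c([N+](=O)[O-])c1` is the third. In this assay compound 3 gives > 27000 nM, also a limit. Compound 1 therefore stands exactly where the whole measured set stands, namely at the limit of > 27000 nM in this assay, at which 3 of the 3 values shown sit. Within the data shown here, no pair of measured compounds differing in one place has been compared, so the size of any single structural change is not known from these numbers.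

Compound 4 `CN1CCN(C(=O)C2CCN(C(=O)c3ccc(S(C)(=O)=O)c([N+](=O)[O-])c3)CC2)CC1` is the compound still to be measured. Its difference from compound 1 is methyl in place of 4-fluorophenyl on an amine nitrogen in a ring. Among the measured compounds shown here, with no measured step available, the expected step from compound 1 to compound 4 is a step that the limit leaves unreadable from compound 1 to compound 4, that is, none beyond the scatter. Compound 4 is expected to give about 30000 nM in this assay, within a range from 20000 nM to 60000 nM, and most probably only a limit will be reported again.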

Compound 4, half-maximal effective concentration: > 27000 nM
Compound 4: only a limit was reported; the forecaster's own chance of this, stated with the estimate: 85%; the middle value is on the limit's open side.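

In this assay no step can be read from compound 1 to compound 4, since both values are limits and not numbers: the limit of > 27000 nM in this assay, at which 4 of the 4 values shown sit. The compounds shown leave open whether any change to the shared core brings an effect that can be read as a number.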